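The source may hold more compounds than are shown below. What is called first, only, known or untested is meant among the compounds shown, and "the series" means these compounds.

In a functional assay on DU-145 cells (Homo sapiens) for cytotoxicity, read by MTT assay (on this read-out higher numbers stand for weaker inhibition and lower numbers for stronger inhibition), compound 1 `CCCCCCC(C)(O)CC(=O)O[C@H](CC=C(C)C)C1=CC(=O)c2c(O)ccc(O)c2C1=O` gives > 100000 nM, which is a limit of the assay and not a number. Compound 2 `CCCC(C)(O)CC(=O)O[C@H](CC=C(C)C)C1=CC(=O)c2c(O)ccc(O)c2C1=O` reads 75000 nM, and compound 3 `CC(C)=CC[C@@H](OC(=O)C1CCCOC1)C1=CC(=O)c2c(O)ccc(O)c2C1=O` reads 29700 nM, the lower of the two numbers. Compound 4 `CC(C)=CC[C@@H](OC(=O)c1ccoc1)C1=CC(=O)c2c(O)ccc(O)c2C1=O` has furan-3-yl in place of oxan-3-yl on a carbonyl carbon. Two measured steps act on this same carbonyl carbon: a 2.5-fold lower number from compound 2 to compound 3 (0.40 log units; beyond the scatter) and an at least 3.3-fold lower number from compound 1 to compound 3 (0.52 log units; beyond the scatter). Both bring oxan-3-yl in for an open chain, so neither tests furan-3-yl directly. Only a small move toward a lower number is therefore expected, with the expected step being a 1.5-fold lower number from compound 3 to compound 4 (0.17 log units; within the scatter). Compound 4 is estimated at 20000 nM, with an expected range of 6000 nM to 60000 nM.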

Compound 4, half-maximal inhibitory concentration: > 100000 nM
Compound 4: only a limit was reported (the forecaster's own chance of this, stated with the estimate: 5%); at least 5.0-fold (0.69 log units) between middle value and limit.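

On this carbonyl carbon, a ring in place of an open chain is not enough for the lower number seen with oxan-3-yl: in this assay, furan-3-yl gives an at least 3.3-fold higher number from compound 3 to compound 4 (0.52 log units; beyond the scatter). Against the open chain, the floor of an at least 1.3-fold higher number from compound 2 to compound 4 (0.12 log units; that floor lies within the scatter) stays within the scatter, and the step between compound 1 and compound 4 cannot be read. Compound 4 thus joins compound 1 at a limit of the assay, which is not a number: the limit of > 100000 nM in this assay, at which 2 of the 4 values shown sit.

The compounds shown leave open whether ring size or ring type separates compound 3 from compound 4. Oxolan-3-yl, a five-membered non-aromatic ring, and phenyl, a six-membered aromatic ring, would each pull these two apart.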